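The source may report more compounds than this note shows. Statements on the series, on what has been measured and on what is new or still open speak of the compounds shown alone.

Measured in a functional assay on KB-V1 cells (Homo sapiens) for cytotoxicity, read by MTT assay, with a stated time of 72 h; on this read-out lower numbers stand for stronger inhibition and higher numbers for weaker inhibition:
- compound 1 `O=C1Nc2ccccc2/C1=N/NC(=S)NCc1ccccc1`: 7630 nM
- compound 2 `O=C1Nc2ccccc2/C1=N/NC(=S)NC1CCCCC1`: 4380 nM
- compound 3 `O=C1Nc2ccccc2/C1=N/NC(=S)Nc1ccc(Cl)cc1`: 4990 nM

Compound 3, at 4990 nM, lies within the scatter of both other compounds: the step is a 1.1-fold higher number from compound 2 to compound 3 (0.06 log units; within the scatter) on one side and a 1.5-fold lower number from compound 1 to compound 3 (0.18 log units; within the scatter) on the other. Compound 4 `O=C1Nc2ccccc2/C1=N/NC(=S)Nc1ccc(Oc2ccccc2)cc1` carries a single structural change: phenoxy in place of chloro on an aromatic carbon.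

The measured steps bear on this change only indirectly. Each replaces the whole group on the amide-type nitrogen, and a 1.7-fold lower number from compound 1 to compound 2 (0.24 log units; within the scatter) also stays within the scatter. Going by the values given here, no measured pair tests a group on the aromatic ring, so the data offer no direct precedent for this replacement. The flat steps seen so far in this assay give no ground for expecting a large shift, so a small move toward a lower number is expected, not clearly beyond the scatter. The expected change is a 1.4-fold lower number from compound 3 to compound 4 (0.15 log units; within the scatter). For compound 4 the estimate is 3500 nM, with an expected range of 1200 nM to 8000 nM.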

Compound 4, half-maximal inhibitory concentration: 1670 nM
Compound 4: the middle estimate sits 2.1-fold (0.32 log units) above what was measured, and the stated range covers the measured number.
By their numbers in this assay, from the lowest: compound 4; then compounds 2, 3 and 1 (each within the scatter of the next).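

In this assay, going by these compounds alone, phenoxy in place of chloro gives a 3.0-fold lower number from compound 3 to compound 4 (0.48 log units; beyond the scatter) and so yields the only step in this set that lies beyond the scatter, though it is modest. The earlier steps shown here each replaced the whole group on the amide-type nitrogen and stayed within the scatter, whereas this one keeps the ring on that nitrogen and changes only the group on its aromatic carbon. This position therefore responds measurably in this assay, and here the entering phenoxy, with its additional six-membered aromatic ring, goes with stronger inhibition than chloro.

As far as these compounds go, whether an amine, a carboxylic acid or a longer chain at this position would shift the number in the same direction remains open. Nothing given here accounts for the step.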